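From a Chlorophenyl to a Furan at the Dienone End

This account rests on a few compounds, and the source may have more. Where it says the series, first, only, none or still open, it means among the compounds named here.

Three dienones built on one shared core have been tested in a functional assay on PC-3 cells (Homo sapiens) for cytotoxicity, read by sulforhodamine B assay, with a stated time of 48 h; a lower number here means a stronger inhibitor, a higher number a weaker inhibitor. Compound 1 `CC1=C(/C=C/C(=O)/C=C/c2ccccc2)C(C)(C)CCC1` gives 12400 nM. Compound 2 `CC1=C(/C=C/C(=O)/C=C/c2ccc(Br)cc2)C(C)(C)CCC1` gives 18900 nM, and compound 3 `CC1=C(/C=C/C(=O)/C=C/c2ccccc2Cl)C(C)(C)CCC1` gives 11300 nM. The steps of a 1.5-fold higher number from compound 1 to compound 2 (0.18 log units; within the scatter) and a 1.1-fold lower number from compound 1 to compound 3 (0.04 log units; within the scatter) are both within the scatter, as is a 1.7-fold lower number from compound 2 to compound 3 (0.22 log units; within the scatter), so compound 3 sits at one end of the three numbers without standing apart from the others. Compound 4 `CC1=C(/C=C/C(=O)/C=C/c2ccoc2)C(C)(C)CCC1` differs from compound 3 by furan-3-yl in place of 2-chlorophenyl on a double-bonded chain carbon bound to a double-bonded chain carbon. Going by the values given here, no measured step swaps the aromatic ring itself; the two aryl-side steps seen, a 1.5-fold higher number from compound 1 to compound 2 (0.18 log units; within the scatter) and a 1.7-fold lower number from compound 2 to compound 3 (0.22 log units; within the scatter), were small. Compound 4 is therefore expected to move little in this assay, a 1.2-fold higher number from compound 3 to compound 4 (0.09 log units; within the scatter). Compound 4 is estimated at 14000 nM, with a range from 6000 nM to 35000 nM.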

Compound 4, half-maximal inhibitory concentration: 50300 nM
Compound 4: the middle estimate sits 3.6-fold (0.56 log units) below what was measured, outside the stated range (above it).
By their numbers in this assay, from the lowest: compounds 3, 1 and 2 (each within the scatter of the next); then compound 4.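

In this assay the group on a double-bonded chain carbon bound to a double-bonded chain carbon does matter: furan-3-yl gives a 4.5-fold higher number from compound 3 to compound 4 (0.65 log units; beyond the scatter) and a 4.1-fold higher number from compound 1 to compound 4 (0.61 log units; beyond the scatter) and a 2.7-fold higher number from compound 2 to compound 4 (0.43 log units; beyond the scatter). Compound 4 is thus the weakest of the four, and exchanging the whole aromatic ring moved the number beyond the scatter, which adding a halogen to the phenyl ring had not done. Nothing available explains this shift. Since the change alters ring size and brings in oxygen together, the compounds shown do not separate the two. On these data alone, how a thiophene or pyridine ring, or a phenyl ring carrying an amine, would behave here remains open.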